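Phenoxy in Place of Phenethyl on the Shared Core

The source may report more compounds than this note shows. Statements on the series, on what has been measured and on what is new or still open speak of the compounds shown alone.

Compound 1, `CCN(CC)CCCC(C)Nc1nc(-c2ccccc2)nc2ccccc12`, in an assay on isolated protein for inhibition of C-C chemokine receptor type 4 (Homo sapiens) (on this read-out lower numbers stand for stronger inhibition and higher numbers for weaker inhibition), gives > 25000 nM, which is a limit of the assay and not a number.
Compound 2, `CCN(CC)CCCC(C)Nc1nc(Cc2ccccc2)nc2ccccc12`, gives 10000 nM in this assay.
Compound 3, `CCN(CC)CCCC(C)Nc1nc(CCCc2ccccc2)nc2ccccc12`, gives > 10000 nM in this assay, a limit rather than a number.

Compound 3 thus stands only at a limit, and among the three values shown one other is also a limit. Going by the values given here, the step that the two limits leave unreadable from compound 1 to compound 3 cannot be sized, and the step of a number no lower from compound 2 to compound 3 (the limit leaves the size open) likewise leaves its size open; the only readable step is an at least 2.5-fold lower number from compound 1 to compound 2 (0.39 log units; beyond the scatter). These readings rest on the limit of > 10000 nM in this assay, at which 1 of the 3 values shown sits, and (the limit of > 25000 nM in this assay, at which 1 of the 3 values shown sits).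

Compound 4, `CCN(CC)CCCC(C)Nc1nc(COc2ccccc2)nc2ccccc12`, differs from compound 3 by phenoxy in place of phenethyl on a saturated chain carbon bound to an aromatic carbon. The entering phenoxy is shorter than the departing phenethyl, and the same change cut one bond further out reads 3-phenylpropyl to phenoxymethyl, which places compound 4 between the benzyl of compound 2 and the 3-phenylpropyl of compound 3 in reach. Compound 2 sits at 10000 nM in this assay. Compound 3 sits only at a limit in this assay. The step that the limit leaves unreadable from compound 3 to compound 4 is expected to be small and of unreadable direction. Compound 4 is therefore estimated at 15000 nM, within 5000 nM to 40000 nM, with a fair chance that only a limit is reported.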

Compound 4, half-maximal inhibitory concentration: 2000 nM
The estimate for compound 4 lay 7.5-fold (0.88 log units) above the measured number, and the stated range ends above it.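

In this assay, phenoxy in place of phenethyl on a saturated chain carbon bound to an aromatic carbon gives an at least 5.0-fold lower number from compound 3 to compound 4 (0.69 log units; beyond the scatter), a step that rests on a limit: the limit of > 10000 nM in this assay, at which 1 of the 4 values shown sits.

The same group also improves on the two other side chains, with a 5.0-fold lower number from compound 2 to compound 4 (0.70 log units; beyond the scatter) and with an at least 12-fold lower number from compound 1 to compound 4 (1.09 log units; beyond the scatter), the second of these again resting on a limit: the limit of > 25000 nM in this assay, at which 1 of the 4 values shown sits.

Until now this position had offered only one readable step, whereas compound 4, whose entering group carries an oxygen counted as one hydrogen-bond acceptor, now has the lowest number of the four, so the all-carbon groups shown do not mark the best that this position allows.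

The compounds shown leave open whether the oxygen itself carries this step or whether the change in the chain does, since no cause can be assigned from these four values. They also leave open whether a phenylthio group or a phenylamino group in the same place would hold the gain, and whether a longer chain ending in phenoxy would keep it.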